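The source may hold more compounds than are shown below. What is called first, only, known or untested is meant among the compounds shown, and "the series" means these compounds.

Compound 1, `O=C(Nc1cccc(-n2cc(-c3ccncc3)c(-c3ccc(Cl)c(O)c3)n2)c1)Nc1ccc(Cl)c(Cl)c1`, in a functional assay on Malme-3M cells (Homo sapiens) for inhibition, read by sulforhodamine B assay, with a stated time of 48 h (a higher number here means a weaker inhibitor of growth, a lower number a stronger inhibitor of growth), gives 8100 nM.
Compound 2, `COc1cc(-c2nn(-c3cccc(NC(=O)Nc4ccc(Cl)c(C(F)(F)F)c4)c3)cc2-c2ccncc2)ccc1Cl`, in this assay gives 2350 nM.

Of the two numbers, compound 2 stands lowest; compound 1 gives a higher number, and the gap between them lies beyond the usual scatter. Compound 3, `O=C(Nc1cccc(-n2cc(-c3ccncc3)c(-c3ccc(Cl)c(O)c3)n2)c1)Nc1ccc(Cl)c(C(F)(F)F)c1`, differs from compound 2 in one place: hydrogen in place of methyl on an oxygen on an aromatic ring. Among the compounds with values here, no measured pair shows this change on its own. Compound 1 does carry the hydroxy, but it also differs from compound 2 elsewhere, so its value says nothing clean about the methyl alone. The step from compound 2 to compound 3 is therefore expected to be modest, a 1.5-fold higher number from compound 2 to compound 3 (0.17 log units; within the scatter), leaning toward a higher number or perhaps not beyond the scatter. Compound 3 is estimated at 3500 nM, within a range of 1200 nM to 10000 nM.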

Compound 3, concentration for total growth inhibition: 1650 nM
Beside the measured number, compound 3's estimate is 2.1-fold (0.33 log units) above it; the measured number falls inside the stated range.
By their numbers in this assay, from the lowest: compounds 3 and 2 (each within the scatter of the next); then compound 1.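

In this assay, within the data shown here, the first clean reading of methoxy to hydroxy on the 4-chloro aryl ring gives a 1.4-fold lower number from compound 2 to compound 3 (0.15 log units; within the scatter), so removing the methyl from this oxygen leaves the number within the scatter. With the hydroxy held fixed, trifluoromethyl in place of chloro gives a 4.9-fold lower number from compound 1 to compound 3 (0.69 log units; beyond the scatter), and of these two single changes only this one lies beyond the scatter. Nothing measured here offers an explanation for either step.

The compounds shown leave open whether an ethoxy group, a longer chain or an amine at this place on the ring would also stay within the scatter. They also leave open whether trifluoromethyl in place of chloro gives a step of similar size when the methoxy is present.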